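The source may report more compounds than this note shows. Statements on the series, on what has been measured and on what is new or still open speak of the compounds shown alone.

In an assay on isolated protein for antagonist activity at Bile acid receptor (Homo sapiens), read by HTRF, with a stated time of 30 min (on this read-out higher numbers stand for weaker inhibition and lower numbers for stronger inhibition), compound 1 `CC(C)(C)c1cc(OC(=O)c2ccc(Cl)cc2)ccc1O` gives > 100000 nM, which is a limit of the assay rather than a number. Compound 2 `CC(C)(C)c1cc(NC(=O)c2ccc(Cl)cc2Cl)cc(C(C)(C)C)c1O` gives > 100000 nM in this assay, again a limit. Going by the values given here, compound 3 `CC(C)(C)c1cc(NC(=O)c2c(Cl)cc(N)cc2Cl)ccc1O` gives 5200 nM in this assay, the only real number among the three, with the other two values sitting at the limit of > 100000 nM in this assay, at which 2 of the 3 values shown sit. Compound 4 `CC(C)(C)c1cc(NC(=O)c2c(Cl)cc(NCc3cccs3)cc2Cl)ccc1O` differs from compound 3 by (thiophen-2-yl)methyl in place of hydrogen on a nitrogen on an aromatic ring. Among the compounds with values here, no measured pair shows what such a change does here, so any expectation rests on compound 3 alone. The step from compound 3 to compound 4 in this assay is estimated as a 2.6-fold lower number from compound 3 to compound 4 (0.41 log units; beyond the scatter), a modest gain in inhibition that may not exceed the scatter. Compound 4 is therefore expected to give about 2000 nM, somewhere between 300 nM and 15000 nM.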

Compound 4, half-maximal inhibitory concentration: 8600 nM
The estimate for compound 4 lay 4.3-fold (0.63 log units) below the measured number; low and high end bracket the measured number.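

In this assay the step is a 1.7-fold higher number from compound 3 to compound 4 (0.22 log units; within the scatter), so putting (thiophen-2-yl)methyl on this nitrogen brings neither a clear gain nor a clear loss. This shows that the nitrogen can carry a group with a whole aromatic ring and still give a real number rather than a limit, which the free amino group could not show. Nothing in the data shown explains this result. As far as these compounds go, it remains open whether methyl, acetyl or a longer chain such as 2-phenylethyl on this nitrogen would give a clearly different number.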